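Working notes: aryl amine exchange and cytotoxicity

This account rests on a few compounds, and the source may have more. Where it says the series, first, only, none or still open, it means among the compounds named here.

Measured so far in a functional assay on PC-3 cells (Homo sapiens) for cytotoxicity, read by MTT assay; a higher number here means a weaker inhibitor, a lower number a stronger inhibitor:
compound 1 `COc1ccc(/C=C/C(=O)c2sc(Nc3ccc(Cl)cc3)nc2C)cc1` gives > 25000 nM, a limit of the assay.
compound 2 `Cc1nc(Nc2ccc(Cl)cc2)sc1C(=O)/C=C/c1ccccc1` gives 24600 nM.
compound 3 `COc1cccc(/C=C/C(=O)c2sc(Nc3cccc(C)c3)nc2C)c1` gives > 25000 nM, a limit of the assay.

Compound 3 sits at the assay limit in this assay, so its value is a limit and not a number, as noted in the limit of > 25000 nM in this assay, at which 2 of the 3 values shown sit. Among the measured compounds shown here, the single measured step, an at least 1.0-fold lower number from compound 1 to compound 2 (0.00 log units; that floor lies within the scatter), is hydrogen in place of methoxy on an aromatic carbon and lies within the scatter, and both compounds in that step carry the 4-chlorophenylamino group that compound 4 `COc1cccc(/C=C/C(=O)c2sc(Nc3ccc(Cl)cc3)nc2C)c1` carries as well. The change from compound 3 to compound 4 is 4-chlorophenyl in place of 3-methylphenyl on a nitrogen on an aromatic ring. For the measured compounds named here, no measured pair isolates this exchange of the aryl amine, so the measured steps give no basis for expecting a step in this assay beyond the scatter in either direction. The one numeric value in the series, from compound 2, sits close to the limit, and the series as shown is narrow. Compound 4 is therefore expected near the limit, with an estimate of 25000 nM ranging from 12000 nM to 50000 nM. The estimated step of a number no higher from compound 3 to compound 4 (the limit leaves the size open) is expected to fall within the scatter.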

Compound 4, half-maximal inhibitory concentration: > 25000 nM
Compound 4 was reported as a limit (the forecaster's own chance of this, stated with the estimate: 60%); the middle value sits exactly at the limit.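

In this assay compound 4 gives > 25000 nM, a limit of the assay, so 4-chlorophenyl in place of 3-methylphenyl on this nitrogen brings no number into view; the steps to compound 4 from compound 3 and from compound 1 cannot be read, since both ends of each are limits. Among the compounds shown here, the one readable step, an at least 1.0-fold higher number from compound 2 to compound 4 (0.00 log units; that floor lies within the scatter), is methoxy in place of hydrogen on an aromatic carbon, and only its floor is known. With this result, the limit now describes most of the series: the limit of > 25000 nM in this assay, at which 3 of the 4 values shown sit.

Going by these compounds, whether the aryl amine position can move a value measurably under the limit remains open, for example with a 4-methoxyphenyl or a pyridyl group on the nitrogen. Equally open, on these data alone, is the effect of a hydroxy or dimethylamino group in place of methoxy.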